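The source may report more compounds than this note shows. Statements on the series, on what has been measured and on what is new or still open speak of the compounds shown alone.

Measured compounds:
compound 1 `O=c1nc2ccccn2cc1Cc1ccc(Br)cc1` — > 1000000 nM
compound 2 `O=c1nc2ccccn2cc1Cc1ccccc1` — > 1000000 nM
compound 3 `O=c1nc2ccc(Br)cn2cc1Cc1cccc(Oc2nc(Cl)c(Cl)cc2Cl)c1` — > 1000000 nM

In a functional assay on HeLa cells (Homo sapiens) for cytotoxicity, read by MTT assay, with a stated time of 24 h (a lower number here means a stronger inhibitor, a higher number a weaker inhibitor), compound 1 stands only at a limit of the assay, not at a number. Compound 2 likewise stands only at a limit. Compound 3 also stands only at a limit. All three values together are summed up by the limit of > 1000000 nM in this assay, at which 3 of the 3 values shown sit. Among the measured compounds shown here, the one measured step, a step that the two limits leave unreadable from compound 1 to compound 2, therefore has no readable size.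

Compound 4 `O=c1nc2ccc(Br)cn2cc1Cc1ccc(Br)cc1` has not yet been measured in this assay. It differs from compound 1 in one place: bromo in place of hydrogen on an aromatic carbon. For the measured compounds named here, no measured step bears on this change directly. The step from compound 1 to compound 2 concerns bromo at another place and is itself unreadable, and compound 3, which carries bromo on its core together with other differences elsewhere, shows only a limit as well. With every known value sitting at the limit, compound 4 is expected to give a limit too, and the expected step that the limit leaves unreadable from compound 1 to compound 4 lies within the scatter, with no direction to it. The estimate for compound 4 in this assay is 2000000 nM, with a range from 500000 nM to 10000000 nM.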

Compound 4, half-maximal inhibitory concentration: 931000 nM
The estimate for compound 4 lay 2.1-fold (0.33 log units) above the measured number, and the stated range covers the measured number.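

In this assay, compound 4 is the only one of the compounds shown that gives a number and not a limit, so bromo on the core, two atoms from the ring nitrogen, can for the first time be set against a neighbouring compound. The change reads as an at least 1.0-fold lower number from compound 1 to compound 4 (0.03 log units; that floor lies within the scatter), which is only a floor, so it fixes no true size and cannot be told apart from no change at all. The earlier compounds could not show that this family reaches a readable value in this cell test, but the single number does not lift the series away from where the others remain: the limit of > 1000000 nM in this assay, at which 3 of the 4 values shown sit.

From the compounds shown here alone, the step between compound 1 and compound 2 cannot be read, so what the other bromo contributes stays unknown, and whether this bromo has any real effect remains unsettled too. Also open, going by these compounds, is whether an amine, a carboxylic acid or a methoxy group at the same ring position would give a number clearly apart from the limit.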